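Mouse microsomal half-life in the urea series: compound 4

The source may report more compounds than this note shows. Statements on the series, on what has been measured and on what is new or still open speak of the compounds shown alone.

Measured in an in vitro ADME assay on microsomes (Mus musculus) for metabolic stability; a higher number here means that the compound lasts longer, a lower number that the compound disappears faster:
- Compound 1 `CNC(=O)Nc1ccc(-c2nc(N3CC4CCC(C3)O4)c3cnn(C(C)C)c3n2)cc1`: > 0.5 h
- Compound 2 `CNC(=O)Nc1ccc(-c2nc(N3CC4CCC(C3)O4)c3cnn(CCN(C)C)c3n2)cc1`: 0.0833 h
- Compound 3 `O=C(Nc1ccc(-c2nc(N3CC4CCC(C3)O4)c3cnn(C4CCC5(CC4)OCCO5)c3n2)cc1)Nc1cccnc1`: > 0.5 h

Compound 3 stands at > 0.5 h, which is a limit and not a number. Its position can only be read coarsely because of the limit of > 0.5 h in this assay, at which 2 of the 3 values shown sit.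

Compound 4 `CCNC(=O)Nc1ccc(-c2nc(N3CC4CCC(C3)O4)c3cnn(C4CCC5(CC4)OCCO5)c3n2)cc1` keeps the rest of compound 3 but has ethyl in place of pyridin-3-yl on an amide-type nitrogen.

Within the data shown here, no measured step covers this exchange. Among the measured compounds shown here, the one measured step, an at least 6.0-fold lower number from compound 1 to compound 2 (0.77 log units; beyond the scatter), lies at a different place, on an aromatic nitrogen, so it gives no direct size for this change. It does show that this assay can separate compounds of this series when a step is large enough. Compound 1, with methyl rather than a ring on the amide-type nitrogen, gives > 0.5 h, likewise a limit. That offers no sign of a loss from a small alkyl group at this place, though it rests on a single compound with a different group on the aromatic nitrogen.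

No step beyond the scatter is therefore expected, in either direction, and the expected change is a step that the limit leaves unreadable from compound 3 to compound 4. For compound 4 the estimated half-life is 0.55 h, with an expected range of 0.25 h to 1.2 h.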

Compound 4, half-life: 0.45 h
Compound 4: the middle estimate sits 1.2-fold (0.09 log units) above what was measured; measured number inside the range.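

In this assay, ethyl in place of pyridin-3-yl on the amide-type nitrogen gives an at least 1.1-fold lower number from compound 3 to compound 4 (0.04 log units; that floor lies within the scatter), so this change is bounded on one side only, and that floor does not establish a real loss. Compound 4 gives 0.45 h, the only value among the compounds shown with this group on the aromatic nitrogen that is a number, which gives later changes at the amide-type nitrogen on this background a measured reference. Compound 3 stays at > 0.5 h, which is a limit, and the true size of the exchange cannot be read because of that limit: the limit of > 0.5 h in this assay, at which 2 of the 4 values shown sit.

Still open is whether the loss of the aromatic ring at this place costs much or nothing, since a large drop and no drop both fit the figures shown. Also open, going by these compounds, is how a chain longer than ethyl, or a chain ending in an amine or a carboxylic acid, would behave on the amide-type nitrogen with this same group on the aromatic nitrogen.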